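A Fluoro Group Enters the Anilino Ring

A few compounds are considered here, and "the series" means these few. Any claim that something is new, unique, unknown or untested is made for them only; others in the source may bear on it.

For the measured compounds named here, compound 2 `S=C(N/N=C/c1ccc(Oc2ccccc2)cc1)Nc1ccccc1` is one of two compounds measured in a physicochemical assay for lipophilicity, in phosphate buffer, measured as octanol-water partition, with a stated time of 24 h; a lower number here means a more polar compound, a higher number a more lipophilic compound. Compound 2 gives 4.9, the lower of the two numbers. Going by the values given here, its only neighbour, compound 1 `S=C(N/N=C/c1ccc(Oc2ccc(Br)cc2)cc1)Nc1ccccc1`, carries a bromo group on an aromatic carbon and gives 5.62. Among the compounds with values here, the single measured step, a number 0.72 log units lower from compound 1 to compound 2 (beyond the scatter), is the one comparison available, and it concerns a halogen leaving an aromatic carbon.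

The next compound, compound 3 `Fc1ccc(NC(=S)N/N=C/c2ccc(Oc3ccccc3)cc2)cc1`, differs from compound 2 in one place: fluoro in place of hydrogen on an aromatic carbon. The change is of the same kind as the measured step, a halogen on an aromatic carbon, but the halogen is fluorine rather than bromine, and the ring is the anilino ring, not the one that carried bromo in compound 1. The step from compound 1 to compound 2 lay beyond the scatter; with fluorine in place of bromine a smaller shift is expected. Compound 3 is therefore expected to sit near compound 2, with a small rise, a number 0.15 log units higher from compound 2 to compound 3 (within the scatter), inside the scatter. The estimate for compound 3 is 5.05, between 4.75 and 5.35.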

Compound 3, partition coefficient: 5.09
Compound 3: the middle estimate sits 0.04 log units below what was measured; low and high end bracket the measured number.
By their numbers in this assay, from the lowest: compounds 2 and 3 (each within the scatter of the next); then compound 1.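

For the compounds shown here, compound 3 gives the first reading of a change on the anilino ring, where earlier the only measured step concerned bromo on the other terminal ring. In this assay, placing fluoro on an aromatic carbon para to a large group gives a number 0.19 log units higher from compound 2 to compound 3 (within the scatter) and so does not separate the fluoro compound from the unsubstituted one: at this position, the exchange of hydrogen for this single fluorine atom leaves the two numbers indistinguishable, unlike the step of a number 0.72 log units lower from compound 1 to compound 2 (beyond the scatter) that involved bromo on a different ring and a different halogen, so the two steps differ in both respects and neither the halogen nor the ring can be singled out as what sets them apart. Nothing in the available information speaks to why this exchange leaves the partition number where it is.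

What the compounds shown leave open is whether a larger or differently built group at this same position, such as chloro, methoxy, an amine or a carboxylic acid, would carry the number beyond the scatter. Going by these compounds, it also remains open whether fluoro on the ring that carried bromo in compound 1 would behave as it does on the anilino ring.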